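Two Quinoxaline-Core Growth Inhibitors and a Proposed Third

The source may hold more compounds than are shown below. What is called first, only, known or untested is meant among the compounds shown, and "the series" means these compounds.

Measured compounds:
compound 1, `Nc1cc(N)c2nc(-c3ccccc3)c(NCc3ccc(Cl)c(Cl)c3)nc2c1`: 4680 nM
compound 2, `CCOC(=O)[C@H](CCC(=O)O)NC(=O)c1ccc(Oc2nc3cc(N)cc(N)c3nc2-c2ccccc2)cc1`: 34700 nM

The two measured compounds share a core carrying two amino groups and a phenyl group, and differ in the side chain attached to the core. In a functional assay on HCT-15 cells (Homo sapiens) for inhibition, read by sulforhodamine B assay, with a stated time of 48 h (a higher number here means a weaker inhibitor of growth, a lower number a stronger inhibitor of growth), compound 1 gives 4680 nM, while compound 2 gives 34700 nM in this assay. Of the two numbers, compound 1 stands at the lower one, and the gap to compound 2 lies beyond the usual scatter of this assay. Among the compounds with values here, no single-change step between measured compounds is available, so the effect of changing the side chain alone has not been isolated.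

Compound 3, `COc1ccc(CNc2nc3cc(N)cc(N)c3nc2-c2ccccc2)cc1`, keeps the core of compound 1 and changes only the pendant aromatic ring: 4-methoxyphenyl in place of 3,4-dichlorophenyl on a saturated chain carbon bound to a nitrogen on an aromatic ring. Nothing measured here speaks to this particular exchange. Since the two measured compounds differ in much larger ways, the step of a 1.5-fold higher number from compound 1 to compound 3 (0.17 log units; within the scatter) is expected to be modest and is not expected to exceed the scatter by much. In this assay compound 3 is accordingly estimated at 7000 nM, with a plausible range from 2000 nM to 25000 nM.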

Compound 3, concentration for 50% growth inhibition: 15800 nM
For compound 3 the middle estimate is 2.3-fold (0.35 log units) below the measured one; measured number inside the range.
By their numbers in this assay, from the lowest: compound 1; then compound 3; then compound 2.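

Replacing 3,4-dichlorophenyl with 4-methoxyphenyl on a saturated chain carbon bound to a nitrogen on an aromatic ring gives the series its first single-change step: in this assay, the exchange produces a 3.4-fold higher number from compound 1 to compound 3 (0.53 log units; beyond the scatter) with the shared core and everything else held constant. The earlier pair differed too widely to isolate any one change, whereas this step shows that the substituents on the pendant aromatic ring alone can move the growth-inhibition number beyond the scatter, here towards weaker inhibition. Nothing available bears on why this exchange has the effect it does.

The step removes the chlorine atoms and introduces the methoxy group in a single exchange, so the compounds shown cannot separate the loss of one from the gain of the other, and a plain phenyl, a 4-chlorophenyl or a 3-methoxyphenyl in the same place would begin to divide the step into its parts. They also leave open whether the same trend would hold with a longer chain joining the pendant ring to the nitrogen, or with an amine or a carboxylic acid on that ring.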